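The source may hold more compounds than are shown below. What is called first, only, known or untested is meant among the compounds shown, and "the series" means these compounds.

Compound 1 `CCCC(=O)Nc1cc(C)c2nc(CCC)n(Cc3ccc(-c4ccccc4C(=O)O)cc3)c2c1` gives 53 nM in an assay on isolated protein for displacement of a labelled ligand from Type-2 angiotensin II receptor (Homo sapiens), with a stated time of 180 min; on this read-out lower numbers stand for stronger inhibition and higher numbers for weaker inhibition. Compound 2 `CCCc1nc2c(C)cc(NC(=O)c3ccc(C)cc3)cc2n1Cc1ccc(-c2ccccc2C(=O)O)cc1` reaches only the limit of this assay, reported as > 10000 nM. That limit is the limit of > 10000 nM in this assay, at which 1 of the 2 values shown sits. Among the compounds with values here, the only measured step, an at least 180-fold higher number from compound 1 to compound 2 (2.27 log units; beyond the scatter), came with 4-methylphenyl in place of propyl on the carbonyl carbon. Compound 3 `CCCc1nc2c(C)cc(NC(=O)OC)cc2n1Cc1ccc(-c2ccccc2C(=O)O)cc1` differs from compound 2 by methoxy in place of 4-methylphenyl on a carbonyl carbon, which removes the 4-methylphenyl again. Because this undoes the change behind an at least 180-fold higher number from compound 1 to compound 2 (2.27 log units; beyond the scatter), a large step back toward compound 1 is expected in this assay. Compound 3 is therefore estimated at 150 nM, within 30 nM to 1500 nM. That estimate means an expected step of an at least 66-fold lower number from compound 2 to compound 3 (1.82 log units; beyond the scatter).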

Compound 3, half-maximal inhibitory concentration: 4370 nM
Estimate against measurement, compound 3: 29-fold (1.46 log units) below; measured number above the stated range.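

Removing the ring from the carbonyl carbon does not by itself restore the strength seen with propyl: methoxy in place of propyl comes with an 82-fold higher number from compound 1 to compound 3 (1.92 log units; beyond the scatter). Methoxy in place of 4-methylphenyl comes with an at least 2.2-fold lower number from compound 2 to compound 3 (0.35 log units; beyond the scatter). That step has no upper bound, because the value of compound 2 is a limit and not a number: the limit of > 10000 nM in this assay, at which 1 of the 3 values shown sits.

On these data alone, what remains open is whether the advantage of compound 1 depends on the length of the propyl chain or on a carbon bound directly to the carbonyl carbon. A longer chain, an ethyl group or an amine on that carbonyl carbon would separate these two readings.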